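From Methoxy to Ethoxy on a Shared Core

The source may hold more compounds than are shown below. What is called first, only, known or untested is meant among the compounds shown, and "the series" means these compounds.

Going by the values given here, in a functional assay on A-431 cells (Homo sapiens) for antiproliferative activity, read by MTT assay, with a stated time of 72 h (a lower number here means a stronger inhibitor, a higher number a weaker inhibitor), compound 1 `COc1ccc(Nc2cc(NC(=O)c3ccccc3)ncn2)cc1` gives 9460 nM, the only actual number available so far. Compound 2 `O=C(Nc1cc(Nc2ccc(Cl)cc2)ncn1)c1ccc(F)cc1` returns only a limit of the assay, > 30000 nM. Compound 1 is therefore the sole numerical reference point.

Compound 3 `CCOc1ccc(Nc2cc(NC(=O)c3ccccc3)ncn2)cc1` keeps the core of compound 1 and differs from it in one place: methyl in place of hydrogen on a saturated chain carbon bound to an oxygen on an aromatic ring. This is methyl in place of hydrogen on a saturated chain carbon bound to an oxygen on an aromatic ring, which turns methoxy into ethoxy. Among the compounds with values here, no measured pair shows what this change does, so no step beyond the usual scatter is expected in this assay, and neither direction is favoured. The expected step of a 1.1-fold lower number from compound 1 to compound 3 (0.02 log units; within the scatter) is accordingly small. Compound 3 is estimated at 9000 nM, with an expected range from 3500 nM to 25000 nM.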

Compound 3, half-maximal inhibitory concentration: 6540 nM
Compound 3: the middle estimate sits 1.4-fold (0.14 log units) above what was measured; measured number inside the range.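

Going by these compounds alone, the change from methoxy to ethoxy, on a saturated chain carbon bound to an oxygen on an aromatic ring, gives the first measured step on the shared core: a 1.4-fold lower number from compound 1 to compound 3 (0.16 log units; within the scatter). In this assay the two compounds therefore cannot be told apart, so adding this methyl leaves the read-out unchanged within the usual scatter. This shows that the position accepts ethoxy in place of methoxy with no step beyond the scatter, which compound 1 alone could not show.

Within the data shown here, compound 2 gives only a limit of the assay, so no step to it can be read: the limit of > 30000 nM in this assay, at which 1 of the 3 values shown sits. Whether a longer chain such as propoxy, or an amine at this place, would move the number beyond the scatter remains open.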